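A few compounds are considered here, and "the series" means these few. Any claim that something is new, unique, unknown or untested is made for them only; others in the source may bear on it.

Compound 1, `O=C(COc1ccc2cc(/C=C3/SC(=O)NC3=O)ccc2c1)Nc1ccccn1`: in an assay on isolated protein for inhibition of histone deacetylase 8 (Homo sapiens), with a stated time of 1 h (a higher number here means a weaker inhibitor, a lower number a stronger inhibitor), compound 1 gives > 50000 nM.
Compound 2, `O=C(COc1ccc2cc(/C=C3/SC(=O)NC3=O)ccc2c1)Nc1cccc(F)n1`: in this assay compound 2 gives 7200 nM.
Compound 3, `O=C(COc1ccc2cc(/C=C3/SC(=O)NC3=O)ccc2c1)Nc1ccc(F)cc1F`: in this assay compound 3 gives > 50000 nM.

The value for compound 3 is a limit of this assay, not a number. The value for compound 1 is likewise a limit, namely (the limit of > 50000 nM in this assay, at which 2 of the 3 values shown sit). Only compound 2 gives a number; the step of an at least 6.9-fold lower number from compound 1 to compound 2 (0.84 log units; beyond the scatter) is at least modest, and an at least 6.9-fold higher number from compound 2 to compound 3 (0.84 log units; beyond the scatter) runs the other way, while a step that the two limits leave unreadable from compound 1 to compound 3 cannot be read. Compound 4, `O=C(COc1ccc2cc(/C=C3/SC(=O)NC3=O)ccc2c1)Nc1ccccc1`, differs from compound 3 by phenyl in place of 2,4-difluorophenyl on an amide-type nitrogen. For the measured compounds named here, no measured step removes fluorine from a phenyl, but because an at least 6.9-fold lower number from compound 1 to compound 2 (0.84 log units; beyond the scatter) shows the added fluoro lowering the number, its removal is not expected to lower it. Compound 3 already stands at the limit, so compound 4 is expected to stay there, with a number no higher from compound 3 to compound 4 (the limit leaves the size open) as the expected step. The estimate for compound 4 in this assay is 50000 nM, between 15000 nM and 150000 nM.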

Compound 4, half-maximal inhibitory concentration: 4500 nM
Estimate against measurement, compound 4: 11-fold (1.05 log units) above; measured number outside the range, below it.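

With phenyl on the amide-type nitrogen, removing the two fluorines gives an at least 11-fold lower number from compound 3 to compound 4 (1.04 log units; beyond the scatter) and so fluoro on this ring does not repeat what it did on pyridin-2-yl. Phenyl in place of the unfluorinated pyridin-2-yl gives an at least 11-fold lower number from compound 1 to compound 4 (1.04 log units; beyond the scatter) while a 1.6-fold lower number from compound 2 to compound 4 (0.20 log units; within the scatter) leaves phenyl and 6-fluoropyridin-2-yl level. From the compounds shown here alone, both large steps start from a limit, so their full size stays open: the limit of > 50000 nM in this assay, at which 2 of the 4 values shown sit.

The compounds shown leave open whether a single fluoro on the phenyl would suffice to raise the number, or which of the two fluorines matters more. Going by these compounds, how a chlorine or a methoxy group on that phenyl would read also remains open.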